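This account rests on a few compounds, and the source may have more. Where it says the series, first, only, none or still open, it means among the compounds named here.

In an ADME assay on a cell-free system (plasma, Homo sapiens) for protein binding, compound 1 (`Cc1ccc([C@@H](C)Oc2cc3onc(CCC(=O)O)c3cc2Cl)nc1`) gives 99.7% and so has the lowest unbound fraction of the three measured compounds. Compound 2 (`Cc1ccc([C@@H](C)Oc2cc3oc(=O)n(CCC(=O)O)c3cc2Cl)nc1`) gives 97.8% on a different core, and compound 3 (`C[C@@H](Oc1cc2oc(=O)n(CCC(=O)O)c2cc1Cl)c1cccnn1`) gives 68.1% on that same core.

Compound 4 (`Cc1ccc([C@@H](C)Oc2cc3onc(CCC(=O)O)c3cc2Cl)nn1`) keeps the core of compound 1 and differs from it in one group only: 6-methylpyridazin-3-yl in place of 5-methylpyridin-2-yl on a saturated chain carbon bound to an oxygen on an aromatic ring and a saturated chain carbon with 6-methylpyridazin-3-yl in place of 5-methylpyridin-2-yl on a saturated chain carbon bound to an oxygen on an aromatic ring and a saturated chain carbon.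

Among the measured compounds shown here, one measured step bears on this change. It is a 15-fold higher unbound fraction from compound 2 to compound 3 (1.16 log units; beyond the scatter) with pyridazin-3-yl in place of 5-methylpyridin-2-yl, and it is large. That step is only a partial guide, as it was seen on the other core and the group entering there has no methyl, whereas the group entering compound 4 keeps one. A rise in the unbound fraction is therefore expected, but a smaller one. The expected size is a 6.7-fold higher unbound fraction from compound 1 to compound 4 (0.82 log units; beyond the scatter) in this assay as estimated here. The estimate for compound 4 is 98% with an expected range from 94.5% to 99.4% in this measurement.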

Compound 4, plasma protein binding: 92.9%
Beside the measured number, compound 4's estimate is 3.6-fold (0.55 log units) (unbound fraction) below it; the whole stated range lies above it.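

In this assay, the exchange on the core of compound 1 gives a 24-fold higher unbound fraction from compound 1 to compound 4 (1.37 log units; beyond the scatter), so a large rise at this position is not confined to the core on which a 15-fold higher unbound fraction from compound 2 to compound 3 (1.16 log units; beyond the scatter) was seen. Unlike that earlier step, this one leaves a methyl on the entering ring: 6-methylpyridazin-3-yl has the same number of heavy atoms as 5-methylpyridin-2-yl and differs in its ring atoms, so the rise does not require the methyl to be lost. Nothing in the available data accounts for the size of this step or says which feature of the entering ring produces it.

The compounds shown leave open how much the methyl itself contributes, since that would take pyridazin-3-yl on the core of compound 1, or 6-methylpyridazin-3-yl on the core of compound 2, to set beside the compounds here. Also open, from the compounds shown here alone, is how other rings on the same saturated chain carbon, such as pyrimidin-2-yl or a plain phenyl, would behave in this assay, and whether a longer chain in place of the one bearing the carboxylic acid would change the size of the step.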